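Propyl in place of cyclohexyl on the amide of compound 1

The source may report more compounds than this note shows. Statements on the series, on what has been measured and on what is new or still open speak of the compounds shown alone.

Compound 1, `COc1ccc(-c2cnc(NC(=O)C3CCCCC3)n2C)cc1`, in a toxicity assay on THP-1 cells (Homo sapiens) for inhibition; a higher number here means that more compound is tolerated, a lower number that less compound is tolerated: > 100000 nM, a limit.
Compound 2, `Cn1c(-c2ccccc2)cnc1NC(=O)c1cccc(Cl)c1`, in this assay: > 50000 nM, a limit.
Compound 3, `Cn1c(-c2ccccc2Br)cnc1NC(=O)c1ccc(F)cc1`, in this assay: > 100000 nM, a limit.

Each of these three values is a limit of the assay and not a number. For compound 1 only such a limit is known in this assay, so its standing among the three cannot be ordered: it sits at the limit of > 100000 nM in this assay, at which 2 of the 3 values shown sit, while compound 2 sits at the limit of > 50000 nM in this assay, at which 1 of the 3 values shown sits. Among the measured compounds shown here, no step between two measured compounds that differ in one place is available, so nothing here shows how a change on the carbonyl carbon shifts the read-out.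

Compound 4, `CCCC(=O)Nc1ncc(-c2ccc(OC)cc2)n1C`, is the unmeasured partner of compound 1. It differs from compound 1 by propyl in place of cyclohexyl on a carbonyl carbon. The carbonyl, its amide-type nitrogen and the shared core are unchanged.

For the measured compounds named here, with all three measured values at limits and no measured step to lean on, the step from compound 1 to compound 4 is expected to be none beyond the scatter, and the most likely outcome is that compound 4 also reaches only a limit. The expected step is a number no higher from compound 1 to compound 4 (the limit leaves the size open). For compound 4 the half-maximal cytotoxic concentration is estimated at 100000 nM, between 40000 nM and 250000 nM.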

Compound 4, half-maximal cytotoxic concentration: > 100000 nM
Compound 4 gave a limit, no number; the forecaster's own chance of this, stated with the estimate: 85%; the middle value lies on the limit itself.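

Compound 1 and compound 4 each reach only a limit in this assay, not a number, so the step between them cannot be read. The compounds shown leave open whether propyl in place of cyclohexyl on the carbonyl carbon shifts the half-maximal cytotoxic concentration at all, and at what concentration any of these compounds becomes toxic to the cells.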